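A few compounds are considered here, and "the series" means these few. Any claim that something is new, unique, unknown or untested is made for them only; others in the source may bear on it.

Compound 1 `CC(C)n1ncc2c(C(=O)Nc3ccccc3)cccc21` and compound 2 `CC(C)n1ncc2c(C(=O)NCc3cn(-c4ccc(F)cc4)nn3)cccc21` share one core, and in a functional assay on MGC-803 cells (Homo sapiens) for inhibition, read by MTT assay, with a stated time of 72 h (a lower number here means a stronger inhibitor, a higher number a weaker inhibitor), compound 1 gives 38500 nM. For compound 2 the reading of > 40000 nM in this assay is a limit of the assay, not a number. Compound 3 `Cc1cccc(-n2cc(CNC(=O)c3cccc4c3cnn4C(C)C)nn2)c1` differs from compound 2 by 3-methylphenyl in place of 4-fluorophenyl on an aromatic nitrogen. For the measured compounds named here, no step between two measured compounds is available here, and compound 2 itself sits at the limit of > 40000 nM in this assay, at which 1 of the 2 values shown sits. The step from compound 2 to compound 3 is therefore expected to be a step that the limit leaves unreadable from compound 2 to compound 3, nothing beyond the usual scatter. Compound 3 is estimated at 45000 nM, within a range from 15000 nM to 130000 nM.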

Compound 3, half-maximal inhibitory concentration: > 40000 nM
Compound 3 ended at the assay's limit (the forecaster's own chance of this, stated with the estimate: 65%); the middle value does not contradict the limit.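

For the compounds shown here, compound 2 and compound 3 both read as limits of the assay, not as numbers, so no step between them can be read: the limit of > 40000 nM in this assay, at which 2 of the 3 values shown sit. In this assay the compounds shown leave open whether 3-methylphenyl and 4-fluorophenyl on the aromatic nitrogen differ at all.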